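Removing the allyl from compound 2: expected shift in potency

The compounds below may be only part of what the source reports. "The series", "measured", "known", "first", "only" and "open" are said of these compounds alone.

Measured so far:
compound 1 `O=C(O)C1CCC(=NOC(c2ccc(OCc3ccc4ccccc4n3)cc2)C2CCCCC2)CC1`, 67 nM
compound 2 `C=CCC(O/N=C(\C)C(=O)O)c1ccc(OCc2ccc3ccccc3n2)cc1`, 142 nM
compound 3 `CCCCC(O/N=C/C(=O)O)c1ccc(OCc2ccc3ccccc3n2)cc1`, 52 nM

In a functional assay for inhibition of Polyunsaturated fatty acid 5-lipoxygenase (Homo sapiens) (a higher number here means a weaker inhibitor, a lower number a stronger inhibitor), compound 2 stands highest of the three numbers. Its nearest neighbour is compound 1, and compound 3 lies furthest from it; both of those gaps are beyond the scatter, so compound 2 is the weakest inhibitor of the three.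

Compound 4 `C/C(=N\OCc1ccc(OCc2ccc3ccccc3n2)cc1)C(=O)O` differs from compound 2 by hydrogen in place of allyl on a saturated chain carbon bound to an aromatic carbon and an oxygen on an unsaturated carbon. Among the compounds with values here, no step between measured compounds shows this change on its own, so its size is not known from the data. The expectation is a modest further weakening, beyond the scatter but not large: compound 4 is estimated at 250 nM, with a range of 90 nM to 700 nM, which means an expected step of a 1.8-fold higher number from compound 2 to compound 4 (0.25 log units; within the scatter).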

Compound 4, half-maximal inhibitory concentration: 1400 nM
Beside the measured number, compound 4's estimate is 5.6-fold (0.75 log units) below it, outside the stated range (above it).
By their numbers in this assay, from the lowest: compounds 3 and 1 (each within the scatter of the next); then compound 2; then compound 4.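

In this assay, hydrogen in place of allyl on a saturated chain carbon bound to an aromatic carbon and an oxygen on an unsaturated carbon gives a 9.9-fold higher number from compound 2 to compound 4 (0.99 log units; beyond the scatter). Within the data shown here, this is the first single-change reading at this position, and it shows that the allyl of compound 2 accounts for a large share of that compound's potency. No supporting data bear on the origin of this loss.

From the compounds shown here alone, it remains open whether the allyl itself is needed or whether another carbon group would serve as well. An ethyl or a propyl chain at this position would separate those two readings.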